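A few compounds are considered here, and "the series" means these few. Any claim that something is new, unique, unknown or untested is made for them only; others in the source may bear on it.

In a functional assay on HCT-116 cells (Homo sapiens) for inhibition, read by MTT assay, with a stated time of 48 h (a higher number here means a weaker inhibitor, a lower number a stronger inhibitor), compound 2, `C=C(C)C(=O)N(Cc1ccc(OC)c(O)c1)c1cc(OC)c(OC)c(OC)c1`, gives 200 nM, the lowest number among the two numbers shown. Compound 1, `COc1ccc(CNc2cc(OC)c(OC)c(OC)c2)cc1C`, gives in this assay a value of 60900 nM, a higher number whose gap to compound 2 lies beyond the usual scatter. Compound 3, `COc1cc(NCc2ccc(Br)cc2)cc(OC)c1OC`, returns in this assay only a limit of > 80000 nM rather than a number; (the limit of > 80000 nM in this assay, at which 1 of the 3 values shown sits).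

The step from compound 2 leads to compound 4, `COc1ccc(CN(C(=O)CO)c2cc(OC)c(OC)c(OC)c2)cc1O`, which has not yet been measured in this assay. The change is hydroxymethyl in place of 1-methylethenyl on a carbonyl carbon. Among the compounds with values here, nothing among the measured compounds shows the effect of exchanging a group on the carbonyl carbon, so no step between measured compounds guides the direction. Compound 4 is expected to give a weaker result than compound 2, with the step from a 15-fold higher number from compound 2 to compound 4 (1.18 log units; beyond the scatter) estimated as a rise well beyond the scatter. The estimate for compound 4 in this assay is 3000 nM, within a range from 600 nM to 20000 nM.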

Compound 4, half-maximal inhibitory concentration: 520 nM
Compound 4: the middle estimate sits 5.8-fold (0.76 log units) above what was measured; the whole stated range lies above it.
By their numbers in this assay, from the lowest: compound 2; then compound 4; then compound 1. At a limit, above all of these: compound 3.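

The earlier compounds shown here offered no measured pair that differed in one place, so the effect of an exchange at this position could not be read from them. In this assay the exchange of 1-methylethenyl for hydroxymethyl on a carbonyl carbon whose other neighbour is an amide-type nitrogen gives a 2.6-fold higher number from compound 2 to compound 4 (0.41 log units; beyond the scatter) and counts as modest, though beyond the scatter, so 1-methylethenyl is not required for a value in this range, and compound 4 holds 520 nM with hydroxymethyl in its place. Nothing measured here bears on why the step has this size.

The compounds shown leave open how other groups on this carbonyl carbon would compare, such as an amine, a carboxylic acid or a longer chain. A single pair also cannot show whether this step would be of similar size on another core.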